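Two dimethylphenyl patterns on a sulfonyl group

A few compounds are considered here, and "the series" means these few. Any claim that something is new, unique, unknown or untested is made for them only; others in the source may bear on it.

Compound 1 `Cc1ccc(S(=O)(=O)c2cnc3cc(F)ccc3c2N2CCC(C)CC2)cc1C`: 90%
Compound 2 `Cc1cc(C)cc(S(=O)(=O)c2cnc3cc(F)ccc3c2N2CCC(C)CC2)c1`: 80%
Compound 3 `Cc1cc(C)cc(S(=O)(=O)c2cnc3ccc(C)cc3c2N2CCC(C)CC2)c1`: 80%

All three values come from an assay on isolated protein for displacement of a labelled ligand from metabotropic glutamate receptor 5 (Homo sapiens), with a stated time of 60 min, tested at 1 uM; on this read-out lower numbers stand for less inhibition and higher numbers for more inhibition at the one concentration tested (going by the name of the read-out). Compound 3 and compound 2 sit level with each other at the digits given, and both stand a little under compound 1, though every gap here lies within the scatter. Compound 2 and compound 1 differ only by 3,4-dimethylphenyl in place of 3,5-dimethylphenyl on a sulfonyl sulfur, and that change gave a number 10 percentage points higher from compound 2 to compound 1 (within the scatter). The difference between the cores of compound 3 and compound 2 is not broken down here.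

Compound 4 `Cc1ccc2ncc(S(=O)(=O)c3ccc(C)c(C)c3)c(N3CCC(C)CC3)c2c1` is not yet measured in this assay; it differs from compound 3 by 3,4-dimethylphenyl in place of 3,5-dimethylphenyl on a sulfonyl sulfur, the same change already seen. Because that change earlier gave a number 10 percentage points higher from compound 2 to compound 1 (within the scatter), compound 4 is expected to show a number 7 percentage points higher from compound 3 to compound 4 (within the scatter). Compound 4 is therefore estimated at 87%, most likely between 74% and 97%.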

Compound 4, a percentage reported as inhibition, at one concentration (the size of the read-out at that concentration, not a potency): 90%
Beside the measured number, compound 4's estimate is 3 percentage points below it; low and high end bracket the measured number.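

In this assay, 3,4-dimethylphenyl in place of 3,5-dimethylphenyl on a sulfonyl sulfur gave a number 10 percentage points higher from compound 3 to compound 4 (within the scatter). Set beside the earlier case, the change reads the same on both cores: the same change on two cores in this assay, a number 10 percentage points higher (within the scatter) from compound 2 to compound 1 and a number 10 percentage points higher (within the scatter) from compound 3 to compound 4, 0 percentage points apart, within the scatter of two such steps. Each step lies within the scatter, however, so the two cores agree without showing that the change itself truly alters inhibition, and a reading at one concentration says nothing about potency.

The compounds shown leave open whether this agreement would hold for other groups on the sulfonyl sulfur, such as a phenyl ring carrying an amine or a carboxylic acid. They also leave open how it would fare on cores beyond these two.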